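Swapping a hydroxyl chain for an amide on the core

The source may report more compounds than this note shows. Statements on the series, on what has been measured and on what is new or still open speak of the compounds shown alone.

Of the compounds shown here, three sharing one core have been tested in a functional assay on OVCAR-8 cells (Homo sapiens) for antiproliferative activity; on this read-out higher numbers stand for weaker inhibition and lower numbers for stronger inhibition. Compound 1 `CNC(=O)C[C@@H]1C[C@@H](c2ccc(F)c(F)c2)[C@H](NC(=O)c2cc(-c3c(Cl)cnn3C)c(Cl)o2)CN1` gives 800 nM. Compound 2 `Cn1ncc(Cl)c1-c1cc(C(=O)N[C@@H]2CN[C@H](CC(=O)NCC(O)CO)C[C@H]2c2ccc(Cl)c(Cl)c2)oc1Cl` gives 5900 nM. Compound 3 `Cn1ncc(Cl)c1-c1cc(C(=O)N[C@@H]2CN[C@H](CCO)C[C@H]2c2ccc(Cl)c(Cl)c2)oc1Cl` gives 610 nM, the lowest of the three numbers, although compound 1 sits within the scatter of it, so the two cannot be ranked.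

Going by the values given here, the single measured step bearing on the side chain is a 9.7-fold lower number from compound 2 to compound 3 (0.99 log units; beyond the scatter), so a shortening of that chain to a hydroxymethyl made the number clearly lower.

Compound 4 `CNC(=O)C[C@@H]1C[C@@H](c2ccc(Cl)c(Cl)c2)[C@H](NC(=O)c2cc(-c3c(Cl)cnn3C)c(Cl)o2)CN1` has not yet been measured. It differs from compound 3 in one place: methylcarbamoyl in place of hydroxymethyl on a saturated chain carbon bound to a saturated ring carbon. Compound 1 carries the same methylcarbamoyl group on a core differing only in its halogens, and its number and that of compound 3 lie within the scatter of one another, which suggests the methylcarbamoyl is tolerated about as well as the hydroxymethyl. The step from compound 2 to compound 3 shows that a much longer carbamoyl chain costs potency, but the methylcarbamoyl is far shorter than that.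

Compound 4 is therefore expected to give about 750 nM in this assay, between 300 nM and 1800 nM. The expected step is a 1.2-fold higher number from compound 3 to compound 4 (0.09 log units; within the scatter), none beyond the usual scatter.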

Compound 4, half-maximal inhibitory concentration: 1130 nM
Beside the measured number, compound 4's estimate is 1.5-fold (0.18 log units) below it; the measured number falls inside the stated range.
By their numbers in this assay, from the lowest: compounds 3, 1 and 4 (each within the scatter of the next); then compound 2.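

Swapping hydroxymethyl for methylcarbamoyl on a saturated chain carbon bound to a saturated ring carbon gives a 1.9-fold higher number from compound 3 to compound 4 (0.27 log units; within the scatter) in this assay, so this position accepts the short amide without a cost that can be told from the scatter. The clear loss seen with compound 2 is now tied to the outer part of its chain: placing hydrogen in place of 1,2-dihydroxyethyl on a saturated chain carbon bound to an amide-type nitrogen gives a 5.2-fold lower number from compound 2 to compound 4 (0.72 log units; beyond the scatter), which shows that the amide alone does not carry that loss. A second comparison concerns the aromatic group on the saturated ring carbon, where 3,4-dichlorophenyl in place of 3,4-difluorophenyl gives a 1.4-fold higher number from compound 1 to compound 4 (0.15 log units; within the scatter), so with methylcarbamoyl on the chain, these two halogen patterns cannot be told apart in this assay.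

Nothing available here explains why these groups behave as they do. From the compounds shown here alone, it also remains open whether an amine or a carboxylic acid at the same chain position would match the hydroxymethyl and methylcarbamoyl groups.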